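The compounds below may be only part of what the source reports. "The series", "measured", "known", "first", "only" and "open" are said of these compounds alone.

Three compounds share one core, a sulfonate ester carrying an iodophenyl group on one side and an acylated aniline on the other, and differ only in the acyl chain. Compound 1 `CCC(=O)Nc1ccc(S(=O)(=O)Oc2ccccc2I)cc1` gives 8100 nM in a functional assay on MCF7 cells (Homo sapiens) for antiproliferative activity, read by sulforhodamine B assay, with a stated time of 48 h; a higher number here means a weaker inhibitor, a lower number a stronger inhibitor. Compound 2 `CC(C)C(=O)Nc1ccc(S(=O)(=O)Oc2ccccc2I)cc1` gives 8100 nM in this assay, and compound 3 `CC(C)(C)C(=O)Nc1ccc(S(=O)(=O)Oc2ccccc2I)cc1` gives 6600 nM in this assay, the lowest of the three numbers, though its gaps to compounds 1 and 2 both fall within the scatter. The steps are small: no change at the digits printed from compound 1 to compound 2 (within the scatter), a 1.2-fold lower number from compound 1 to compound 3 (0.09 log units; within the scatter) and a 1.2-fold lower number from compound 2 to compound 3 (0.09 log units; within the scatter). Compound 4 `O=C(CCCl)Nc1ccc(S(=O)(=O)Oc2ccccc2I)cc1` takes the chain one step further, with 2-chloroethyl in place of tert-butyl on a carbonyl carbon. For the measured compounds named here, the most relevant comparison is the ethyl-to-tert-butyl step from compound 1 to compound 3, which stayed within the scatter, and the remaining steps point the same way; the chlorine carries no precedent among the measured compounds. Compound 4 is therefore expected to land close to its neighbours, at an estimated 7500 nM in this assay, within a range from 3500 nM to 16000 nM, a step of a 1.1-fold higher number from compound 3 to compound 4 (0.06 log units; within the scatter) that is expected to stay within the scatter.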

Compound 4, half-maximal inhibitory concentration: 8900 nM
Estimate against measurement, compound 4: 1.2-fold (0.07 log units) below; measured number inside the range.
By their numbers in this assay, from the lowest: compounds 3, 1, 2 and 4 (each within the scatter of the next).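

In this assay this place on the carbonyl carbon also takes a chain carrying chlorine, not only plain alkyl groups: the exchanges read (a 1.3-fold higher number from compound 3 to compound 4 (0.13 log units; within the scatter)) and (a 1.1-fold higher number from compound 2 to compound 4 (0.04 log units; within the scatter)). The most direct reading is chloro in place of hydrogen on the chain of compound 1 (a 1.1-fold higher number from compound 1 to compound 4 (0.04 log units; within the scatter)), so this first heteroatom on the acyl chain leaves the number inside the scatter of the alkyl series. Nothing available explains why the four acyl chains read alike.

As far as these compounds go, whether this flat picture would hold for an amine or a carboxylic acid at the end of the chain remains open. So does the reading for a longer chain, or for a phenyl group on the carbonyl carbon.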